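Swapping pyridin-3-yl for pyrazin-2-yl on a short-lived compound

The compounds below may be only part of what the source reports. "The series", "measured", "known", "first", "only" and "open" are said of these compounds alone.

Among the compounds with values here, in an ADME assay on the whole organism for metabolic stability, with Rattus norvegicus as the target (on this read-out higher numbers stand for a longer-lived compound and lower numbers for a shorter-lived compound), compound 1 `CSCC[C@H](NC(=O)c1ccc(CN(Cc2ccccc2)c2cccnc2)cc1-c1ccccc1C)C(=O)O` gives 0.83 h, and it is the only compound with an actual number so far. In this assay, compound 2 `CSCC[C@H](NC(=O)c1ccc(CN(CC2CCCCC2)c2cccnc2)cc1-c1ccccc1C)C(=O)O` gives < 0.4 h, which is a limit of the assay and not a number. Within the data shown here, the single measured step is an at least 2.0-fold lower number from compound 1 to compound 2 (0.31 log units; beyond the scatter), and it comes with cyclohexyl in place of phenyl on a saturated chain carbon bound to a nitrogen on an aromatic ring. The size of that step is tied to the limit of < 0.4 h in this assay, at which 1 of the 2 values shown sits.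

Compound 3 `CSCC[C@H](NC(=O)c1ccc(CN(Cc2ccccc2)c2cnccn2)cc1-c1ccccc1C)C(=O)O` differs from compound 1 in one place, with pyrazin-2-yl in place of pyridin-3-yl on an amine nitrogen. Among the measured compounds shown here, the measured step changes a different group, so it sets no size for this exchange, and no measured step touches the pyridin-3-yl group. The reading of compound 1 at 0.83 h therefore remains the anchor, and no shift beyond the scatter is expected. The expected step is a 1.1-fold lower number from compound 1 to compound 3 (0.04 log units; within the scatter). The estimate for compound 3 is 0.75 h, with an expected range from 0.4 h to 1.5 h.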

Compound 3, half-life: < 0.4 h
Compound 3 was reported as a limit; the forecaster's own chance of this, stated with the estimate: 15%; middle value at least 1.8-fold (0.27 log units) away from the limit.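

Within the data shown here, the exchange at this amine nitrogen, where no earlier step had touched the pyridin-3-yl group, shows that the group cannot be swapped for pyrazin-2-yl without loss: in this assay the change gives an at least 2.0-fold lower number from compound 1 to compound 3 (0.31 log units; beyond the scatter). Compound 3 gives < 0.4 h, which is a limit of the assay and not a number. Changes to two different groups on the same amine nitrogen, phenyl on its chain and pyridin-3-yl, have now each taken compound 1 to this limit, so the full size of neither step can be read, and each marks only a smallest possible drop: the limit of < 0.4 h in this assay, at which 2 of the 3 values shown sit.

The compounds shown leave open whether the loss follows from the second ring nitrogen of pyrazin-2-yl as such or from where that nitrogen sits, a question that a plain phenyl or a pyrimidin-5-yl group on the amine nitrogen would help to separate. They also leave open whether any group at this place, such as pyridin-4-yl, would give a longer half-life than compound 1 does, at 0.83 h.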